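Cyano in place of chloro on the benzamide ring

The source may hold more compounds than are shown below. What is called first, only, known or untested is meant among the compounds shown, and "the series" means these compounds.

Measured compounds:
compound 1, `O=C(Nc1cccc(-c2oc3cc(-c4ccc(F)cc4)ccc3c(=O)c2O)c1)c1ccc(Cl)cc1`, 10800 nM
compound 2, `Cc1cccc(C(=O)Nc2cccc(-c3oc4cc(-c5ccc(F)cc5)ccc4c(=O)c3O)c2)c1`, 16500 nM
compound 3, `O=C(Nc1cccc(-c2oc3cc(-c4ccc(F)cc4)ccc3c(=O)c2O)c1)c1cnc(Cl)nc1Cl`, a limit of > 100000 nM

In a functional assay on A549 cells (Homo sapiens) for antiproliferative activity, read by CCK-8 assay, with a stated time of 72 h (on this read-out lower numbers stand for stronger inhibition and higher numbers for weaker inhibition), compound 1 gives 10800 nM, the lowest of the two numbers shown. Compound 2 gives 16500 nM in this assay, and the step of a 1.5-fold higher number from compound 1 to compound 2 (0.18 log units; within the scatter) lies within the scatter. For compound 3 this assay reports only a limit, > 100000 nM, as stated in the limit of > 100000 nM in this assay, at which 1 of the 3 values shown sits. The steps of an at least 9.2-fold higher number from compound 1 to compound 3 (0.96 log units; beyond the scatter) and an at least 6.0-fold higher number from compound 2 to compound 3 (0.78 log units; beyond the scatter) are therefore the only ones beyond the scatter, and both concern the exchange of a phenyl ring for a 2,4-dichloropyrimidin-5-yl ring.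

Compound 4, `N#Cc1ccc(C(=O)Nc2cccc(-c3oc4cc(-c5ccc(F)cc5)ccc4c(=O)c3O)c2)cc1`, differs from compound 1 as follows: cyano in place of chloro on an aromatic carbon. Going by the values given here, no measured step covers such a change on the same phenyl ring; the nearest, the step to compound 2, altered a substituent on that ring and stayed within the scatter. Among the compounds with values here, the phenyl ring itself is kept, so no step like that to compound 3 is expected. Compound 4 is therefore expected to give about 15000 nM in this assay, between 6000 nM and 40000 nM, a step of a 1.4-fold higher number from compound 1 to compound 4 (0.14 log units; within the scatter) that is expected to stay within the scatter.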

Compound 4, half-maximal inhibitory concentration: 2360 nM
Compound 4: the middle estimate sits 6.4-fold (0.80 log units) above what was measured; the whole stated range lies above it.
By their numbers in this assay, from the lowest: compound 4; then compounds 1 and 2 (each within the scatter of the next). At a limit, above all of these: compound 3.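

Exchanging chloro for cyano on this phenyl ring is the first change shown that lowers the number in this assay beyond the scatter, with a 4.6-fold lower number from compound 1 to compound 4 (0.66 log units; beyond the scatter), so the group at this place, para to a large group, does matter, although the earlier step of a 1.5-fold higher number from compound 1 to compound 2 (0.18 log units; within the scatter) had shown no such change. Compound 4 has the lowest number of the series, and its lead also holds against the 3-methylphenyl amide, with a 7.0-fold lower number from compound 2 to compound 4 (0.84 log units; beyond the scatter), and against the 2,4-dichloropyrimidin-5-yl amide, with an at least 42-fold lower number from compound 3 to compound 4 (1.62 log units; beyond the scatter). The last of these steps is only a bound, as compound 3 is reported at a limit: the limit of > 100000 nM in this assay, at which 1 of the 4 values shown sits.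

This single pair leaves open whether the gain is particular to cyano or would also appear with a carboxylic acid, an amine or a methyl ester at this place. The compounds shown also do not tell how cyano would fare elsewhere on the ring, or why the number falls.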